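This account rests on a few compounds, and the source may have more. Where it says the series, first, only, none or still open, it means among the compounds named here.

Compound 1, `COc1cc(CNC(=S)NCC(COC(=O)C(C)(C)C)Cc2ccc(C)c(C)c2)cc(Br)c1O`, in an assay on CHO cells for displacement of a labelled ligand from transient receptor potential cation channel subfamily V member 1 (Rattus norvegicus) (a higher number here means a weaker inhibitor, a lower number a stronger inhibitor), gives 33.1 nM.
Compound 2, `COc1cc(CNC(=S)NCC(COC(=O)C(C)(C)C)Cc2ccc(C)c(C)c2)cc(I)c1O`, in this assay gives 232 nM.
Compound 3, `COc1cc(CNC(=S)NC(CCc2ccc(C)c(C)c2)COC(=O)C(C)(C)C)c(Br)cc1O`, in this assay gives 109 nM.

Compound 1 and compound 2 share one core and differ by a single change, (iodo in place of bromo on an aromatic carbon), which brought a 7.0-fold higher number from compound 1 to compound 2 (0.85 log units; beyond the scatter). Compound 3 has the same atoms as compound 1 joined differently; how the two cores differ is not broken down here. Compound 4, `COc1cc(CNC(=S)NC(CCc2ccc(C)c(C)c2)COC(=O)C(C)(C)C)c(I)cc1O`, is not yet measured and arises from compound 3 by iodo in place of bromo on an aromatic carbon. This is the same kind of change as before, not the same: earlier the bromo sat ortho to a hydroxy group, meta to a large group and meta to a methoxy group; here it sits ortho to a large group, meta to a hydroxy group and para to a methoxy group. In this assay compound 4 is expected to show a 4.1-fold higher number from compound 3 to compound 4 (0.62 log units; beyond the scatter), a weakening resting on a 7.0-fold higher number from compound 1 to compound 2 (0.85 log units; beyond the scatter) but kept smaller since the surroundings of the change differ. The estimate for compound 4 is 450 nM, between 150 nM and 1400 nM.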

Compound 4, inhibition constant: 140 nM
The estimate for compound 4 lay 3.2-fold (0.51 log units) above the measured number; measured number outside the range, below it.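

On this second core, iodo in place of bromo gave a 1.3-fold higher number from compound 3 to compound 4 (0.11 log units; within the scatter), so here the swap made no clear difference. Set beside the earlier case, the size of this change did not carry from one core to the other in this assay: the same change on two cores in this assay, a 7.0-fold higher number (0.85 log units; beyond the scatter) from compound 1 to compound 2 and a 1.3-fold higher number (0.11 log units; within the scatter) from compound 3 to compound 4, 5.5-fold (0.74 log units) apart, beyond the scatter of two such steps. What this does not show is the reason, as the two cores have their atoms joined differently and the halogen has different surroundings on each, and two pairs of compounds cannot give a rule for the whole series.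

The compounds shown leave open how chloro or fluoro would compare with bromo and iodo on either core. They also leave open whether a methyl or a nitrile at the same place would be tolerated.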